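The compounds below may be only part of what the source reports. "The series", "measured", "known", "first", "only" and "open" are said of these compounds alone.

Measured so far in a functional assay on ileum for inhibition of histamine H1 receptor (Cavia porcellus); on this read-out higher numbers stand for weaker inhibition and lower numbers for stronger inhibition:
- compound 1 `CCCOCCn1c(N2CCN(C)CC2)nc2ccccc21`: 20 nM
- compound 2 `CCCSCn1c(N2CCN(C)CC2)nc2ccccc21`: 68 nM

Within the data shown here, compound 2 gives the higher of the two numbers in this assay, with compound 1 as its only neighbour; the step is a 3.4-fold higher number from compound 1 to compound 2 (0.53 log units; beyond the scatter), which lies beyond the scatter.

The next compound, compound 3 `COCCn1c(N2CCN(C)CC2)nc2ccccc21`, is not yet measured. Against compound 2 the change is methoxymethyl in place of propylsulfanyl on a saturated chain carbon bound to an aromatic nitrogen. Among the measured compounds shown here, only one measured step touches this part of the molecule, the one from compound 1 to compound 2, which replaced an ether oxygen chain with a sulfur-linked chain and gave a modest rise in the number. Compound 3 moves back to an oxygen-containing chain, though a shorter one; nothing measured tells how the shorter chain alone weighs.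

On that basis compound 3 is expected to land between the two measured neighbours, closer to compound 1, with a 2.3-fold lower number from compound 2 to compound 3 (0.36 log units; beyond the scatter) as the expected step. The estimate for compound 3 in this assay is 30 nM, with a range from 10 nM to 90 nM.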

Compound 3, half-maximal inhibitory concentration: 13 nM
Compound 3: middle estimate off by 2.3-fold (0.36 log units), on the high side; measured number inside the range.
By their numbers in this assay, from the lowest: compounds 3 and 1 (each within the scatter of the next); then compound 2.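

In this assay the (propylsulfanyl)methyl chain now stands apart from two ether chains: going to 2-methoxyethyl gives a 5.2-fold lower number from compound 2 to compound 3 (0.72 log units; beyond the scatter) and shows that the higher number of compound 2 is not set against a single ether chain only. Hydrogen in place of ethyl on a saturated chain carbon bound to an oxygen on a saturated carbon gives a 1.5-fold lower number from compound 1 to compound 3 (0.19 log units; within the scatter) and leaves compound 1 and compound 3 not distinguishable on this read-out, so within these two ether chains the length makes no visible difference. No measurement on hand gives a reason for either step.

Compound 2 differs from compound 3 in both the sulfur and the chain around it, so a 2-(methylsulfanyl)ethyl chain would be needed to separate the two. Also open, going by these compounds, is how a longer ether chain, or a chain carrying an amine or a carboxylic acid, would read.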